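From methoxy to hydroxy on the aryl ring of compound 3

The source may hold more compounds than are shown below. What is called first, only, known or untested is meant among the compounds shown, and "the series" means these compounds.

Measured so far:
compound 1 `O=C(Nc1cccc(-n2cc(-c3ccncc3)c(-c3ccc(Cl)c(O)c3)n2)c1)Nc1cccc(C(F)(F)F)c1`, > 32500 nM
compound 2 `COc1cc(-c2nn(-c3cccc(NC(=O)c4cccc(C(F)(F)F)c4)c3)cc2-c2ccncc2)ccc1Cl`, > 50000 nM
compound 3 `COc1cc(-c2nn(-c3cccc(NC(=O)Nc4ccc(Cl)c(Cl)c4)c3)cc2-c2ccncc2)ccc1Cl`, 7320 nM

Going by the values given here, in a functional assay on SK-MEL-28 cells (Homo sapiens) for inhibition, read by sulforhodamine B assay, with a stated time of 48 h (on this read-out lower numbers stand for stronger inhibition of growth and higher numbers for weaker inhibition of growth), compound 3 gives 7320 nM, the only finite number among the three. The value of compound 1, > 32500 nM, is a limit of the assay. The value of compound 2, > 50000 nM, is likewise a limit. Among the compounds with values here, the one measured step, an at least 6.8-fold lower number from compound 2 to compound 3 (0.83 log units; beyond the scatter), changes the group on the carbonyl carbon, not the oxygen. Compound 4 `O=C(Nc1cccc(-n2cc(-c3ccncc3)c(-c3ccc(Cl)c(O)c3)n2)c1)Nc1ccc(Cl)c(Cl)c1` differs from compound 3 by hydrogen in place of methyl on an oxygen on an aromatic ring. Within the data shown here, no measured step touches that oxygen, so none bears directly on this change. Compound 1 and compound 3 carry hydroxy and methoxy, but they differ elsewhere as well, so only their two values are shown. The step from compound 3 to compound 4 is therefore expected to stay within the scatter, a 1.1-fold higher number from compound 3 to compound 4 (0.04 log units; within the scatter). Compound 4 is estimated at 8000 nM, between 3000 nM and 25000 nM.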

Compound 4, concentration for total growth inhibition: 9850 nM
The estimate for compound 4 lay 1.2-fold (0.09 log units) below the measured number, within the range that was stated.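

In this assay, going by these compounds alone, the change from methoxy to hydroxy gives a 1.3-fold higher number from compound 3 to compound 4 (0.13 log units; within the scatter), the first step to isolate this oxygen, and it shows that methyl and hydrogen there cannot be told apart when 3,4-dichlorophenyl is present. With hydroxy in place, the group on the amide-type nitrogen still matters, giving an at least 3.2-fold lower number from compound 1 to compound 4 (0.51 log units; beyond the scatter). Compound 1 stands at a limit of the assay, not at a number: the limit of > 32500 nM in this assay, at which 1 of the 4 values shown sits. The compounds shown leave open whether an ethoxy group or an amine at this position would give a similar number.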